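Changing the piperidine substituent: compound 3 to compound 4

The source may report more compounds than this note shows. Statements on the series, on what has been measured and on what is new or still open speak of the compounds shown alone.

The compounds share one core and differ in the group carried on the saturated chain. In a functional assay on DU-145 cells (Homo sapiens) for antiproliferative activity, read by MTT assay, with a stated time of 72 h (a lower number here means a stronger inhibitor, a higher number a weaker inhibitor), compound 1 `CCN(CC)CCCOc1cc2ncnc(Nc3ccc(C#N)cc3)c2cc1OC` gives 68900 nM, compound 2 `COc1cc2c(Nc3ccc(C#N)cc3)ncnc2cc1OCCCN1CCC(C)CC1` gives 16600 nM and compound 3 `CCOC(=O)C1CCN(CCCOc2cc3ncnc(Nc4ccc(C#N)cc4)c3cc2OC)CC1` gives 52300 nM. The step of a 1.3-fold lower number from compound 1 to compound 3 (0.12 log units; within the scatter) is small, whereas a 3.2-fold higher number from compound 2 to compound 3 (0.50 log units; beyond the scatter) is not, so compound 3 sits with compound 1 in the upper part of these three numbers.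

Compound 4 `COc1cc2c(Nc3ccc(C#N)cc3)ncnc2cc1OCCCN1CCC(N(C)C)CC1` carries dimethylamino in place of ethoxycarbonyl on a saturated ring carbon, (dimethylamino in place of ethoxycarbonyl on a saturated ring carbon). For the measured compounds named here, no measured compound has dimethylamino on this ring, so the evidence is indirect. The closest step is a 3.2-fold higher number from compound 2 to compound 3 (0.50 log units; beyond the scatter), a change at the same ring carbon, but with methyl rather than dimethylamino as the partner group. The step of a 4.2-fold lower number from compound 1 to compound 2 (0.62 log units; beyond the scatter) is also modest, so the changes measured on this group so far remain limited in size. On this basis, a small move to a lower number is expected in this assay, probably not beyond the scatter. The expected change is a 1.6-fold lower number from compound 3 to compound 4 (0.21 log units; within the scatter). The estimated value for compound 4 is 32000 nM, with an expected range of 12000 nM to 80000 nM.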

Compound 4, half-maximal inhibitory concentration: 28300 nM
Estimate against measurement, compound 4: 1.1-fold (0.05 log units) above; low and high end bracket the measured number.
By their numbers in this assay, from the lowest: compounds 2, 4, 3 and 1 (each within the scatter of the next, the first and the last beyond it).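

In this assay the saturated ring carbon three ring bonds from the ring nitrogen now carries methyl, ethoxycarbonyl or dimethylamino, and dimethylamino cannot be separated from ethoxycarbonyl (a 1.8-fold lower number from compound 3 to compound 4 (0.27 log units; within the scatter)) or from methyl (a 1.7-fold higher number from compound 2 to compound 4 (0.23 log units; within the scatter)), although methyl and ethoxycarbonyl stand apart from each other. The whole 4-(dimethylamino)piperidin-1-yl group does separate from diethylamino on the chain (a 2.4-fold lower number from compound 1 to compound 4 (0.39 log units; beyond the scatter)), but only as a modest step, and it joins the 4-methylpiperidin-1-yl group in doing so, while the 4-(ethoxycarbonyl)piperidin-1-yl group does not. No measurement is available that would tie any of these steps to a cause.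

As far as these compounds go, whether a free carboxylic acid, a primary amine or a hydroxyl on this ring carbon would stay among the numbers seen so far remains open, as does the effect of a morpholine or a piperazine in place of the piperidine. A longer chain between the ring nitrogen and the oxygen on the aromatic ring is also untested among these compounds, so it is unknown whether any change here can give more than a modest step.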